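The source may hold more compounds than are shown below. What is called first, only, known or untested is meant among the compounds shown, and "the series" means these compounds.

In an assay on MCF7 cells for inhibition of Serine-protein kinase ATM (Homo sapiens), read by immunofluorescence, with a stated time of 1 h (on this read-out lower numbers stand for stronger inhibition and higher numbers for weaker inhibition), compound 2 `COc1cc2ncnc(-n3nc(-c4ccccn4)nc3N)c2cc1OCCCNC(=O)OC(C)(C)C` gives 900 nM, and compound 1 `COc1cc2ncnc(-n3nc(-c4ccccn4)nc3N)c2cc1OCCCN1CC(C)OC(C)C1` gives 1600 nM in this assay, two numbers that lie within the scatter of each other. Within the data shown here, the only measured step, a 1.8-fold lower number from compound 1 to compound 2 (0.25 log units; within the scatter), concerns a different replacement and therefore bears only loosely on the next move. Compound 3 `COc1cc2ncnc(-n3nc(-c4ccccn4)nc3N)c2cc1OCCCCNC(=O)OC(C)(C)C` carries ((tert-butoxycarbonyl)amino)methyl in place of (tert-butoxycarbonyl)amino on a saturated chain carbon, three bonds along the chain from an oxygen on an aromatic ring. Among the measured compounds shown here, no measured pair shows such a lengthening, so no step beyond the scatter is expected, namely no change at the digits printed from compound 2 to compound 3 (within the scatter). Compound 3 is accordingly estimated at 900 nM, with a range from 300 nM to 2700 nM.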

Compound 3, half-maximal inhibitory concentration: 800 nM
Beside the measured number, compound 3's estimate is 1.1-fold (0.05 log units) above it, within the range that was stated.
By their numbers in this assay, from the lowest: compounds 3, 2 and 1 (each within the scatter of the next).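

In this assay, among these compounds, lengthening the chain by replacing (tert-butoxycarbonyl)amino with ((tert-butoxycarbonyl)amino)methyl gives a 1.1-fold lower number from compound 2 to compound 3 (0.05 log units; within the scatter) and is the first change of chain length seen at this position. Replacing 2,6-dimethylmorpholin-4-yl with ((tert-butoxycarbonyl)amino)methyl gives a 2.0-fold lower number from compound 1 to compound 3 (0.30 log units; within the scatter) and likewise does not leave the scatter. Nothing available explains either step. Still open, on these data alone, is whether a free amine or a carboxylic acid in place of the (tert-butoxycarbonyl)amino end would hold these numbers. Also open, as far as these compounds go, is whether a longer chain, such as 2-((tert-butoxycarbonyl)amino)ethyl, would do so.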